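This account rests on a few compounds, and the source may have more. Where it says the series, first, only, none or still open, it means among the compounds named here.

Measured so far, in an ADME assay on BV-2 cells (Mus musculus) for cytotoxicity, read by MTT assay, with a stated time of 48 h, tested at 5 uM; a higher number here means a weaker effect of the compound at the concentration tested, a lower number a stronger effect:
- compound 1 `Cc1ccc(S(=O)(=O)n2cc(/C=N\c3ccc(N4CCOCC4=O)cc3)c3ccccc32)cc1` gives 89.1%
- compound 2 `O=C1COCCN1c1ccc(/N=C\c2cn(C(=O)c3ccccc3)c3ccccc23)cc1` gives 87.3%

Compound 2 stands lowest of the two numbers shown, but the only neighbour is compound 1, and the step of a number 1.8 percentage points lower from compound 1 to compound 2 (within the scatter) lies within the scatter, so no order between them can be read.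

The step to compound 3 `O=C1COCCN1c1ccc(/N=C\c2cn(C(=O)c3ccc(Cl)cc3)c3ccccc23)cc1` is chloro in place of hydrogen on an aromatic carbon. Among the measured compounds shown here, no measured step touches this kind of change; the single step on record, a number 1.8 percentage points lower from compound 1 to compound 2 (within the scatter), concerns the group on the aromatic nitrogen and was within the scatter. On that basis no step beyond the scatter is expected in this assay for compound 3, in either direction.

For compound 3 the expected value is 85%, with a range of 70% to 97%, which means an expected step of a number 2.3 percentage points lower from compound 2 to compound 3 (within the scatter) that stays within the scatter.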

Compound 3, a percentage reported as activity, at one concentration (the size of the read-out at that concentration, not a potency): 93.7%
Beside the measured number, compound 3's estimate is 8.7 percentage points below it; the range from low to high includes it.
By their numbers in this assay, from the lowest: compounds 2, 1 and 3 (each within the scatter of the next).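

Chloro in place of hydrogen on an aromatic carbon, para to a large group, gives a number 6.4 percentage points higher from compound 2 to compound 3 (within the scatter) in this assay, so this position takes the chloro group without a step beyond the scatter. Changing the whole group on the aromatic nitrogen, with (4-chlorophenyl)carbonyl in place of (4-methylphenyl)sulfonyl, gives a number 4.6 percentage points higher from compound 1 to compound 3 (within the scatter), so the sulfonyl and carbonyl links remain indistinguishable here even with chloro present. No supporting measurement bears on this result.

Going by these compounds, an amine or a carboxylic acid on that same aromatic carbon remains open, as does a longer chain in place of the benzoyl group on the aromatic nitrogen. On these data alone, whether any change in these two places moves the number beyond the scatter also remains open.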